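The source may report more compounds than this note shows. Statements on the series, on what has been measured and on what is new or still open speak of the compounds shown alone.

Compounds measured so far: compound 1 `CN1CCC(C(=O)N2Cc3c(NC(=O)C4CCC4)n[nH]c3C2(C)C)CC1` with 140 nM, compound 2 `CN1CCC(C(=O)N2Cc3c(NC(=O)c4ccc(Cl)cc4)n[nH]c3C2(C)C)CC1` with 120 nM, and compound 3 `CC(=O)N1CCC(C(=O)N2Cc3c(NC(=O)c4ccc(F)cc4)n[nH]c3C2(C)C)CC1` with > 10000 nM.

In a functional assay on A2780 cells (Homo sapiens) for antiproliferative activity, read by fluorescence, with a stated time of 72 h (on this read-out lower numbers stand for stronger inhibition and higher numbers for weaker inhibition), compound 1 gives 140 nM. Compound 2 gives 120 nM in this assay, and the step of a 1.2-fold lower number from compound 1 to compound 2 (0.07 log units; within the scatter) shows that exchanging the group on the carbonyl carbon in this way leaves the read-out essentially unchanged. Compound 3 stands apart from both: its result in this assay is a limit of the assay, > 10000 nM, and not a number, as recorded under (the limit of > 10000 nM in this assay, at which 1 of the 3 values shown sits).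

Compound 4 `CC(C)(C)C(=O)N1Cc2c(NC(=O)c3ccc(F)cc3)n[nH]c2C1(C)C` has not yet been measured. It differs from compound 3 by tert-butyl in place of 1-acetylpiperidin-4-yl on a carbonyl carbon. Among the measured compounds shown here, neither measured step touches this change: the only step with numbers on both sides, a 1.2-fold lower number from compound 1 to compound 2 (0.07 log units; within the scatter), alters a different part of the molecule. So nothing measured says in which direction the step from compound 3 to compound 4 should go, and the only firm point is that compound 3 sits at the limit. The account therefore expects compound 4 to remain weak in this assay, with an estimate of 6000 nM spanning 1000 nM to 30000 nM, which means an expected step of an at least 1.6-fold lower number from compound 3 to compound 4 (0.22 log units; that floor lies within the scatter).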

Compound 4, half-maximal inhibitory concentration: 270 nM
The estimate for compound 4 lay 22-fold (1.35 log units) above the measured number, and the stated range ends above it.
By their numbers in this assay, from the lowest: compounds 2, 1 and 4 (each within the scatter of the next, the first and the last beyond it). At a limit, above all of these: compound 3.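

With tert-butyl in place of 1-acetylpiperidin-4-yl on the carbonyl carbon, this assay records an at least 37-fold lower number from compound 3 to compound 4 (1.56 log units; beyond the scatter), the only step shown at this position and the only one beyond the scatter. The earlier step, which exchanged the group on the other carbonyl carbon, left the read-out essentially unchanged, whereas this one shows that the read-out responds strongly at this position and that neither the six-membered ring nor its acetyl is required for compound 4 to give 270 nM. The step gives only a floor for the size of the change, because compound 3 is recorded at a limit of the assay and not at a number: the limit of > 10000 nM in this assay, at which 1 of the 4 values shown sits.

The compounds shown leave open which part of the 1-acetylpiperidin-4-yl group, the ring or its acetyl, goes with the limit of compound 3, and how the read-out would respond to a primary amine, a carboxylic acid or a longer alkyl chain in place of tert-butyl on this carbonyl carbon. This pair also carries only 4-fluorophenyl on the other carbonyl carbon, so whether the step holds with cyclobutyl or 4-chlorophenyl there remains unanswered.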